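The source may hold more compounds than are shown below. What is called first, only, known or untested is meant among the compounds shown, and "the series" means these compounds.

Measured compounds so far:
- compound 1 `CCO[C@@]1(CC)CCC2(CO1)[C@@H]1CCC3=C4[C@@H](CC3=O)[C@H](C(=O)OC)C[C@@]42CN(C)C1`: in a functional assay on SMMC-7721 cells (Homo sapiens) for cytotoxicity, read by MTT assay, with a stated time of 48 h (on this read-out lower numbers stand for stronger inhibition and higher numbers for weaker inhibition), compound 1 gives > 40000 nM, which is a limit of the assay and not a number.
- compound 2 `CC[C@]1(OC)CCC2(CO1)[C@@H]1CCC3=C4[C@@H](CC3=O)[C@H](C(=O)OC)C[C@@]42CN(C)C1`: in this assay compound 2 gives > 40000 nM, again a limit of the assay.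
- compound 3 `CCC1=CCC2(CO1)[C@@H]1CCC3=C4[C@H](CC3=O)[C@H](C(=O)OC)C[C@@]42CN(C)C1`: in this assay compound 3 gives > 40000 nM, also a limit of the assay.

All three measured values sit at the same limit, as recorded in the limit of > 40000 nM in this assay, at which 3 of the 3 values shown sit. The change from compound 2 to compound 1 is methyl in place of hydrogen on a saturated chain carbon bound to an oxygen on a saturated carbon, and the step that the two limits leave unreadable from compound 2 to compound 1 cannot be read, since both ends are limits. The difference between the cores of compound 2 and compound 3 is not broken down here.

Compound 4 `COC(=O)[C@@H]1C[C@@]23CN(C)C[C@@H](CCC4=C2[C@@H]1CC4=O)C31CC=C(C(C)C)OC1` has not yet been measured in this assay. It differs from compound 3 by methyl in place of hydrogen on a saturated chain carbon bound to a double-bonded ring carbon and a saturated chain carbon. This is the same kind of change as that from compound 2 to compound 1, but the place is not the same: there the added methyl sits on a saturated chain carbon bound to an oxygen on a saturated carbon, here on a saturated chain carbon bound to a double-bonded ring carbon and a saturated chain carbon.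

Since every measured compound, including compound 3 with > 40000 nM, sits at the limit (the limit of > 40000 nM in this assay, at which 3 of the 3 values shown sit), the step from compound 3 to compound 4 in this assay is expected to be a step that the limit leaves unreadable from compound 3 to compound 4, most likely unreadable in the same way. Compound 4 is therefore estimated at 60000 nM in this assay, with a plausible range from 20000 nM to 200000 nM, and a limit rather than a number is expected.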

Compound 4, half-maximal inhibitory concentration: > 40000 nM
Compound 4: a limit, no number (the forecaster's own chance of this, stated with the estimate: 85%); the middle value does not contradict the limit.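

No new step can be read: compound 3 and compound 4 both stand at a limit and not at a number, so the change from ethyl to isopropyl stays unreadable, as do all other steps in the series. The limit is shared by every compound shown: the limit of > 40000 nM in this assay, at which 4 of the 4 values shown sit.

In this assay the compounds shown leave open how far each lies beyond that limit, and which change to the shared core, if any, would give a readable value.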